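A pyridine in place of the cyanophenyl

This account rests on a few compounds, and the source may have more. Where it says the series, first, only, none or still open, it means among the compounds named here.

In an in vitro functional assay on HEK293S cells for agonist activity at Glucose-dependent insulinotropic receptor (Homo sapiens), read by HTRF and cAMP accumulation, with a stated time of 45 min (a lower number here means that less compound is needed, a higher number that more compound is needed for the effect), compound 2 `C[C@@H]1CN(C(=O)OC(C)(C)C)CCN1c1ncc(OCc2ccc(C#N)cc2)cn1` gives 39 nM, the second highest of the three numbers. Compound 1 `C[C@@H]1CN(C(=O)OC(C)(C)C)CCN1c1ncc(OCc2ccc(S(=O)(=O)N(C)C)cc2)cn1` gives 79 nM in this assay, and compound 3 `C[C@@H]1CN(C(=O)OC(C)(C)C)CCN1c1ncc(OCc2ccc(S(C)(=O)=O)cc2C#N)cn1` gives 16 nM. The only single-point step among these is a 2.0-fold lower number from compound 1 to compound 2 (0.31 log units; beyond the scatter), a modest gain for the nitrile over the dimethylsulfamoyl group. Compound 4 `Cc1cnccc1COc1cnc(N2CCN(C(=O)OC(C)(C)C)C[C@H]2C)nc1` differs from compound 2 by 3-methylpyridin-4-yl in place of 4-cyanophenyl on a saturated chain carbon bound to an oxygen on an aromatic ring. For the measured compounds named here, no measured step covers this exchange: the nitrile that compound 2 carries is removed and a ring nitrogen enters instead, so the step from compound 1 to compound 2 bears on it only indirectly, by showing that the group on this ring matters at about the modest level seen there. For compound 4 the expected step is therefore a 2.6-fold higher number from compound 2 to compound 4 (0.41 log units; beyond the scatter), taken with wide uncertainty. Compound 4 is estimated to give 100 nM in this assay, within a range from 25 nM to 400 nM.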

Compound 4, half-maximal effective concentration: 184 nM
Compound 4: middle estimate off by 1.8-fold (0.26 log units), on the low side; low and high end bracket the measured number.
By their numbers in this assay, from the lowest: compound 3; then compound 2; then compound 1; then compound 4.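

In this assay the exchange of 4-cyanophenyl for 3-methylpyridin-4-yl on a saturated chain carbon bound to an oxygen on an aromatic ring gives a 4.7-fold higher number from compound 2 to compound 4 (0.67 log units; beyond the scatter). The earlier step changed only a group carried on the ring, whereas this one replaces the ring itself, and it shows that this position responds to such a replacement, with more compound needed. Even so, compound 4 still gives a measurable number, 184 nM, so the exchange does not abolish the effect. Nothing available bears on the reason for this step.

The compounds shown leave open how much of the step belongs to the ring nitrogen, the methyl or the departing nitrile, as all three change together. Going by these compounds, whether a plain pyridin-4-yl would behave like 3-methylpyridin-4-yl also stays open.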